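This account rests on a few compounds, and the source may have more. Where it says the series, first, only, none or still open, it means among the compounds named here.

Compound 1 `CCCCNc1nc(N)nc2c1CNCC2` was examined in an assay on HEK293 cells for agonist activity at Toll-like receptor 8 (Homo sapiens), read by a luciferase reporter, with a stated time of 6 h; a higher number here means that more compound is needed for the effect, a lower number that less compound is needed. In this assay compound 1 gives 7.2 uM, the highest of the two numbers recorded so far. For the measured compounds named here, its only measured neighbour is compound 2 `CCCCNc1nc(N)nc2c1CN(Cc1ccc(C(F)(F)F)cc1)CC2`, which carries a substituent on the amine nitrogen in a ring that is bare in compound 1; in this assay compound 2 gives 0.23 uM, a number far below that of compound 1 and well beyond the usual scatter. Compound 3 `CCCCNc1nc(N)nc2c1CN(C(=O)c1cscn1)CC2` also builds on the core of compound 1, with a different kind of group on that same amine nitrogen in a ring. (1,3-thiazol-4-yl)carbonyl in place of hydrogen on an amine nitrogen in a ring Whether this carbonyl-linked group behaves like the group of compound 2 cannot be read from one pair, so a smaller step is expected. Because compound 2 reached 0.23 uM after substitution on the same nitrogen, compound 3 is expected to need less compound than compound 1, with an expected step of a 3.6-fold lower number from compound 1 to compound 3 (0.56 log units; beyond the scatter). The estimate for compound 3 in this assay is 2 uM, with a range from 0.5 uM to 8 uM.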

Compound 3, minimum effective concentration: 0.5 uM
Beside the measured number, compound 3's estimate is 4.0-fold (0.60 log units) above it; low and high end bracket the measured number.
By their numbers in this assay, from the lowest: compound 2; then compound 3; then compound 1.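

The amine nitrogen in a ring now carries a second substituent that lowers the number in this assay, and it is a different kind of group: (1,3-thiazol-4-yl)carbonyl, attached through a carbonyl and bearing a five-membered aromatic ring with 2 hetero atoms, gives a 14-fold lower number from compound 1 to compound 3 (1.16 log units; beyond the scatter). The large drop seen with compound 2 is therefore not confined to one substituent on this nitrogen, although compound 3 at 0.5 uM still stands above compound 2 at 0.23 uM. Nothing measured here offers an explanation for the size of this step.

The compounds shown leave open whether the carbonyl link or the thiazole ring matters more, a question that an acetyl group or a benzoyl group on the same nitrogen could help to separate. On these data alone, it also remains open how small a substituent can be and still lower the number, as a methyl group on that nitrogen would test.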